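An ester swapped for an amide on the carbonyl

A few compounds are considered here, and "the series" means these few. Any claim that something is new, unique, unknown or untested is made for them only; others in the source may bear on it.

Compound 1 `CCCCCNC(=O)/C=C/c1ccccc1` gives 60% in a functional assay on the whole organism for inhibition, with Brassica rapa subsp. chinensis as the target, with a stated time of 3 days, tested at 100 ppm; a higher number here means more inhibition of growth at the concentration tested, a lower number less inhibition of growth
Compound 2 `CCC(C)OC(=O)/C=C/c1ccccc1` gives 18% in this assay

Compound 2 holds the lower of the two numbers, and the gap up to compound 1 lies beyond the usual scatter of repeated measurements. Compound 3 `CC(C)NC(=O)/C=C/c1ccccc1` has not been measured yet. It places isopropylamino in place of sec-butoxy on a carbonyl carbon. This turns the ester of compound 2 into an amide. The only amide measured so far is compound 1, at 60%, which is a single data point and carries a different chain. An upward step beyond the scatter is therefore expected, with the estimated a number 24 percentage points higher from compound 2 to compound 3 (beyond the scatter) in this assay stopping short of certainty. The estimate for compound 3 is 42% (range 20% to 65%).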

Compound 3, percent growth inhibition at one concentration: 39%
For compound 3 the middle estimate is 3 percentage points above the measured one; low and high end bracket the measured number.
By their numbers in this assay, from the lowest: compound 2; then compound 3; then compound 1.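

In this assay, the change on the carbonyl carbon can now be read as a single swap: isopropylamino in place of sec-butoxy gives a number 21 percentage points higher from compound 2 to compound 3 (beyond the scatter). The amide-type nitrogen also proves to be a place that matters, since isopropyl in place of pentyl gives a number 21 percentage points lower from compound 1 to compound 3 (beyond the scatter), so the amide alone does not set the number. Nothing available explains either step.

Still open, as far as these compounds go, is how much of the first step belongs to the nitrogen in place of the oxygen and how much to the change of carbon chain, a question that a sec-butylamino group on the same carbonyl carbon would address. It is also unclear whether the second step follows chain length or branching, which a straight propyl chain on the nitrogen would help to separate.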